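The source may report more compounds than this note shows. Statements on the series, on what has been measured and on what is new or still open speak of the compounds shown alone.

In a functional assay on A549 cells (Homo sapiens) for antiproliferative activity, read by MTT assay, with a stated time of 72 h (a lower number here means a stronger inhibitor, a higher number a weaker inhibitor), three compounds with a shared core have been measured, differing only in the ring on a carbon with a double bond to nitrogen. Compound 1 `O=C(N/N=C/c1ccccc1)Nc1ccc(Oc2ccnc3[nH]ccc23)c(F)c1`, with plain phenyl, gives 2500 nM. Compound 2 `O=C(N/N=C/c1ccc(O)cc1O)Nc1ccc(Oc2ccnc3[nH]ccc23)c(F)c1` gives 5840 nM, and compound 3 `O=C(N/N=C/c1ccc(O)c(Br)c1)Nc1ccc(Oc2ccnc3[nH]ccc23)c(F)c1` gives 9250 nM. Compound 3 cannot be told apart from compound 2, since a 1.6-fold higher number from compound 2 to compound 3 (0.20 log units; within the scatter) is within the scatter. Both carry higher numbers than compound 1, through the modest steps of a 2.3-fold higher number from compound 1 to compound 2 (0.37 log units; beyond the scatter) and a 3.7-fold higher number from compound 1 to compound 3 (0.57 log units; beyond the scatter).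

Compound 4 `CN(C)CCn1cccc1/C=N/NC(=O)Nc1ccc(Oc2ccnc3[nH]ccc23)c(F)c1` puts 1-(2-(dimethylamino)ethyl)-1H-pyrrol-2-yl in place of 3-bromo-4-hydroxyphenyl on a carbon with a double bond to nitrogen. Among the measured compounds shown here, no measured compound carries a pyrrole or a dimethylamino chain, so the measured steps offer only partial guidance. The closest guide is that compound 1, whose ring has no hydroxy or bromo substituent, sits lower, as a 3.7-fold higher number from compound 1 to compound 3 (0.57 log units; beyond the scatter) shows. Compound 4 also lacks both substituents, so a modest move towards a lower number is expected, though with wide uncertainty given the new ring and chain. The expected step is a 3.7-fold lower number from compound 3 to compound 4 (0.57 log units; beyond the scatter). For compound 4 the estimated value is 2500 nM, within an expected range from 500 nM to 10000 nM.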

Compound 4, half-maximal inhibitory concentration: "not active" (no number reported)
Compound 4 has no reported number here; there is nothing to compare the estimate with.
By their numbers in this assay, from the lowest: compound 1; then compounds 2 and 3 (each within the scatter of the next).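

In this assay, among the compounds shown here, compound 4 is reported only as "not active", without a number, so no step linking it to compound 1, compound 2 or compound 3 can be read. The compounds shown leave open whether the pyrrole ring or the dimethylamino chain goes with this result. No other data here bear on it.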